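Aryl ether to benzylamine on the shared diamino core

The compounds below may be only part of what the source reports. "The series", "measured", "known", "first", "only" and "open" are said of these compounds alone.

Three compounds of this series have numbers in a functional assay on SK-MEL-5 cells (Homo sapiens) for inhibition, read by sulforhodamine B assay, with a stated time of 48 h; on this read-out lower numbers stand for stronger inhibition of growth and higher numbers for weaker inhibition of growth. Compound 1 `CCOC(=O)[C@H](CCC(=O)O)NC(=O)c1ccc(Sc2nc3cc(N)cc(N)c3nc2-c2ccccc2)cc1` gives 32400 nM. Compound 2 `Nc1cc(N)c2nc(-c3ccccc3)c(Oc3ccc(F)cc3)nc2c1` gives 31600 nM, the second highest of the three numbers; its gap to compound 1 is within the scatter, so nothing separates the two. Compound 3 `COc1cc(CNc2nc3cc(N)cc(N)c3nc2-c2ccccc2)cc(OC)c1OC` gives 7760 nM, a lower number than compound 2 by a gap beyond the scatter. Compound 3 is the only one of the three whose group on the core is attached through an amino nitrogen rather than through an oxygen or a sulfur, and it carries the lowest number of the three.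

Compound 4 `Nc1cc(N)c2nc(-c3ccccc3)c(NCc3ccc(F)cc3)nc2c1` is not yet measured. It differs from compound 2 in one place: (4-fluorobenzyl)amino in place of 4-fluorophenoxy on an aromatic carbon. The ring bearing a fluorine stays; the oxygen link gives way to a (4-fluorobenzyl)amino group on the aromatic carbon next to the ring nitrogen.

For the measured compounds named here, no step between measured compounds repeats this change, so the size of the step is uncertain. As far as these compounds go, compound 3, with an amino link on the same core, gives 7760 nM, and this is the only pointer toward a lower number for compound 4; whether the rest of its group matters is unknown. In this assay compound 4 is expected to give 15000 nM, between 4000 nM and 50000 nM. The expected step of a 2.1-fold lower number from compound 2 to compound 4 (0.32 log units; beyond the scatter) is downward, probably just beyond the scatter.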

Compound 4, concentration for total growth inhibition: 3630 nM
Beside the measured number, compound 4's estimate is 4.1-fold (0.62 log units) above it; measured number outside the range, below it.
By their numbers in this assay, from the lowest: compound 4; then compound 3; then compounds 2 and 1 (each within the scatter of the next).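

In this assay, for the compounds shown here, the step of an 8.7-fold lower number from compound 2 to compound 4 (0.94 log units; beyond the scatter) is the first comparison between compounds that differ in one place, and it shows that the group on this aromatic carbon, next to the ring nitrogen and ortho to a phenyl group, is not indifferent to the exchange. The fluorine-bearing ring is present on both sides of the step, while (4-fluorobenzyl)amino brings a nitrogen link, a hydrogen-bond donor absent from 4-fluorophenoxy, and a carbon between the link and the ring, so the step alone cannot assign the change to any one of these differences. Nothing measured here accounts for the size of this step.

The compounds shown leave open whether the lower number follows the nitrogen link or the added carbon: a 4-fluoroanilino group would keep the nitrogen without that carbon, and a (4-fluorobenzyl)oxy group would keep the carbon without the nitrogen. As far as these compounds go, the role of the fluorine is also open, since a plain benzylamino group on the shared core would test it directly.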